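The source may report more compounds than this note shows. Statements on the series, on what has been measured and on what is new or still open speak of the compounds shown alone.

Working notes on the series. Among the compounds with values here, in a functional assay on B16 cells (Mus musculus) for cytotoxicity, read by MTT assay, with a stated time of 48 h (on this read-out higher numbers stand for weaker inhibition and lower numbers for stronger inhibition), compound 2 `O=[N+]([O-])c1ccc(-c2cn(Cc3ccccc3)nn2)cc1` gives 5120 nM, the only numerical value recorded so far. Compound 1 `COc1ccc(-c2cn(CCCO)nn2)cc1` is reported in this assay only as a limit, > 100000 nM. Within the data shown here, the one piece of evidence on hand is the limit of > 100000 nM in this assay, at which 1 of the 2 values shown sits. Compound 3 `COc1ccc(-c2cn(Cc3ccccc3)nn2)cc1` has not yet been measured in this assay; it differs from compound 2 by methoxy in place of nitro on an aromatic carbon. Among the measured compounds shown here, no step between measured compounds is available to size this change. In this assay a shift toward weaker inhibition beyond the scatter is expected, with a real chance that only a limit is returned. The expected step is a 3.9-fold higher number from compound 2 to compound 3 (0.59 log units; beyond the scatter). For compound 3 the estimate in this assay is 20000 nM, ranging from 5000 nM to 100000 nM.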

Compound 3, half-maximal inhibitory concentration: > 100000 nM
Compound 3: only a limit was reported (the forecaster's own chance of this, stated with the estimate: 35%); at least 5.0-fold (0.69 log units) between middle value and limit.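

Within the data shown here, on the aromatic carbon para to a large group, methoxy in place of nitro gives the first readable step: an at least 19-fold higher number from compound 2 to compound 3 (1.29 log units; beyond the scatter) in this assay. Compound 3 is reported only as a limit, so this size is a floor and the true step may be larger. Compounds 1 and 3 both stand as limits, and the step between them cannot be read. Open, going by these compounds, is whether nitro alone gives a numerical value at this position, or whether an amine, a nitrile or a fluorine there would also. Also open, on these data alone, is how phenyl in place of 2-hydroxyethyl acts with nitro kept on the ring.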